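Loss of two methyls on the thiophene ring

The source may hold more compounds than are shown below. What is called first, only, known or untested is meant among the compounds shown, and "the series" means these compounds.

Among the measured compounds shown here, compound 1 `Cc1cc(-c2nc3sc(C)cn3c2/C=N/NC(=N)N)c(C)s1` gives 19100 nM in a functional assay on cells (Cancer cell lines, Homo sapiens) for inhibition (on this read-out higher numbers stand for weaker inhibition of growth and lower numbers for stronger inhibition of growth), the lower of the two numbers measured so far. Compound 2 `Cc1cn2c(/C=N/Nc3ccccn3)c(-c3ccc(Cl)c([N+](=O)[O-])c3)nc2s1` gives 38900 nM in this assay, a gap from compound 1 that lies beyond the scatter. Compound 3 `Cc1cn2c(/C=N/NC(=N)N)c(-c3ccsc3)nc2s1` differs from compound 1 by thiophen-3-yl in place of 2,5-dimethylthiophen-3-yl on an aromatic carbon. For the measured compounds named here, no measured pair shows this change, so the step is expected to stay small, within the scatter or slightly toward weaker inhibition, estimated as a 1.3-fold higher number from compound 1 to compound 3 (0.12 log units; within the scatter). For compound 3 the expected value in this assay is 25000 nM, with a range from 8000 nM to 80000 nM.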

Compound 3, concentration for total growth inhibition: 20000 nM
For compound 3 the middle estimate is 1.3-fold (0.10 log units) above the measured one, and the stated range covers the measured number.
By their numbers in this assay, from the lowest: compounds 1, 3 and 2 (each within the scatter of the next, the first and the last beyond it).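

Replacing 2,5-dimethylthiophen-3-yl with thiophen-3-yl on this aromatic carbon gives a step within the scatter in this assay (a 1.0-fold higher number from compound 1 to compound 3 (0.02 log units; within the scatter)). In this pair, the two thiophene methyls can therefore be lost without a measurable change on this read-out. No available evidence bears on why this step is so small.

Going by these compounds, whether an amine, a carboxylic acid or a longer chain on the thiophene would move the number remains open. So does the effect of keeping only one of the two methyls.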